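The source may report more compounds than this note shows. Statements on the series, on what has been measured and on what is new or still open speak of the compounds shown alone.

Measured compounds in the series:
- compound 1 `CC(C)c1ccc(-n2nc(-c3ccc(C(F)(F)F)cc3O)nc2-c2ccccc2O)cc1`: 108%
- compound 2 `Oc1cc(C(F)(F)F)ccc1-c1nc(-c2ccccc2O)n(-c2ccc(Cl)cc2)n1`: 96.1%
- compound 3 `Oc1cc(C(F)(F)F)ccc1-c1nc(-c2ccccc2O)n(-c2cccc(F)c2)n1`: 98.3%

All three were run in a functional assay on PC-12 cells (Rattus norvegicus) for cytotoxicity, read by MTT assay, with stated times of 2 h and 24 h, tested at 10 uM; on this read-out higher numbers stand for a stronger effect at the one concentration tested and lower numbers for a weaker effect. On these numbers compound 1 stands highest of the three; compound 3 is nearest to it, the gap from compound 1 to compound 3 being a number 9.7 percentage points lower from compound 1 to compound 3 (within the scatter) (within the scatter), while compound 2 is furthest, the gap being a number 11.9 percentage points lower from compound 1 to compound 2 (beyond the scatter) (beyond the scatter). Compound 2 and compound 3 lie within the scatter of each other, as a number 2.2 percentage points higher from compound 2 to compound 3 (within the scatter) shows.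

Compound 4 `Oc1cc(C(F)(F)F)ccc1-c1nc(-c2ccccc2O)n(-c2cccc(Cl)c2)n1` has not yet been measured in this assay. It differs from compound 1 in one place: 3-chlorophenyl in place of 4-isopropylphenyl on an aromatic nitrogen

Among the compounds with values here, two measured steps bear on this change. Replacing isopropyl with chloro on an aromatic carbon, in the step from compound 1 to compound 2, gave a number 11.9 percentage points lower from compound 1 to compound 2 (beyond the scatter); replacing the 4-isopropylphenyl with a 3-fluorophenyl on the aromatic nitrogen, in the step from compound 1 to compound 3, gave a number 9.7 percentage points lower from compound 1 to compound 3 (within the scatter). Compound 4 combines a halogen on the ring with the 3-position of compound 3, so a modest downward step of about the same size is expected, a number 11 percentage points lower from compound 1 to compound 4 (beyond the scatter), at the edge of the scatter. The estimate for compound 4 in this assay is 97%, with a range from 87% to 107%.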

Compound 4, a percentage reported as activity, at one concentration (the size of the read-out at that concentration, not a potency): 100%
Beside the measured number, compound 4's estimate is 3 percentage points below it; low and high end bracket the measured number.
By their numbers in this assay, from the lowest: compounds 2, 3, 4 and 1 (each within the scatter of the next, the first and the last beyond it).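

In this assay, chloro in place of fluoro on the aryl group on the aromatic nitrogen gives a number 1.7 percentage points higher from compound 3 to compound 4 (within the scatter), and 3-chlorophenyl in place of 4-chlorophenyl gives a number 3.9 percentage points higher from compound 2 to compound 4 (within the scatter), so among compounds 2, 3 and 4 neither the identity of the halogen nor its place on this phenyl ring separates the numbers. 3-Chlorophenyl in place of 4-isopropylphenyl gives a number 8 percentage points lower from compound 1 to compound 4 (within the scatter), so a chloro-bearing ring on this nitrogen does not in itself set a compound beyond the scatter from compound 1: of the three halogenated compounds, only compound 2 stands there. No supporting measurement is available to account for any of these steps.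

Still open, on these data alone, is whether an aminomethyl group, a carboxylic acid or a longer alkyl chain on this phenyl ring would give a step beyond the scatter in either direction. All the compounds shown also keep the 2-hydroxyphenyl group and the trifluoromethyl-bearing hydroxyphenyl group, so the effect of replacing either one, for instance with a methoxy in place of a hydroxyl, remains unknown.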